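Swapping the aromatic ring on the amide-bearing carbon

The compounds below may be only part of what the source reports. "The series", "measured", "known", "first", "only" and "open" are said of these compounds alone.

Three cyclic compounds with a shared core have been measured in an assay on isolated protein for displacement of a labelled ligand from Oxytocin receptor (Homo sapiens); a higher number here means a weaker inhibitor, a lower number a stronger inhibitor. Compound 1 `Cc1ccc([C@H](C(=O)N(C)C)N2C(=O)[C@@H](C3Cc4ccccc4C3)NC(=O)[C@H]2CC(C)C)cn1` gives 1.59 nM, compound 2 `CC[C@H](C)[C@@H]1C(=O)N[C@H](C2Cc3ccccc3C2)C(=O)N1[C@@H](C(=O)N(C)C)c1ccc(C)[n+]([O-])c1` gives 1 nM, and compound 3 `CC(C)C[C@@H]1C(=O)N[C@H](C2Cc3ccccc3C2)C(=O)N1[C@@H](C(=O)N(C)C)c1ccc(O)nc1` gives 3.16 nM. Compound 2 thus has the lowest of the three numbers; its nearest neighbour is compound 1, within the scatter, while compound 3 lies beyond the scatter from it.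

Compound 4 `CC[C@H](C)[C@@H]1C(=O)N[C@H](C2Cc3ccccc3C2)C(=O)N1[C@@H](C(=O)N(C)C)c1cc(C)cnc1C` has not been measured yet. It differs from compound 2 by a group of 8 heavy atoms (7 carbon, 1 nitrogen; one six-membered aromatic ring with 1 hetero atom) in place of a group of 8 heavy atoms (6 carbon, 1 nitrogen, 1 oxygen; one six-membered aromatic ring with 1 hetero atom), on a saturated chain carbon bound to an amide-type nitrogen in a ring and a carbonyl carbon; the entering group is the 2,5-dimethylpyridin-3-yl, placed on a saturated chain carbon bound to an amide-type nitrogen in a ring and a carbonyl carbon.

Among the compounds with values here, only one measured step touches the same aromatic ring: a 2.0-fold higher number from compound 1 to compound 3 (0.30 log units; within the scatter). Compound 1 and compound 2 differ in two places at once, so their values show only that both fall close together. With a single ring change of this kind staying within the scatter, no step beyond the scatter is expected for a 1.8-fold higher number from compound 2 to compound 4 (0.26 log units; within the scatter).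

Compound 4 is therefore estimated at 1.8 nM, within a range from 0.7 nM to 5 nM, in this assay.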

Compound 4, inhibition constant: 0.794 nM
Compound 4: the middle estimate sits 2.3-fold (0.36 log units) above what was measured; low and high end bracket the measured number.
By their numbers in this assay, from the lowest: compounds 4, 2, 1 and 3 (each within the scatter of the next, the first and the last beyond it).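

Replacing the whole aromatic group of compound 2 with the 2,5-dimethylpyridin-3-yl, on a saturated chain carbon bound to an amide-type nitrogen in a ring and a carbonyl carbon, gives in this assay a step of a 1.3-fold lower number from compound 2 to compound 4 (0.10 log units; within the scatter) and so leaves the number unchanged within the scatter. Within the data shown here, the only earlier single-place step, a 2.0-fold higher number from compound 1 to compound 3 (0.30 log units; within the scatter), exchanged one substituent on the ring, whereas this step exchanges the entire group, and it shows that a group of 7 carbon and 1 nitrogen can stand in for one of 6 carbon, 1 nitrogen and 1 oxygen while compound 4 remains at 0.794 nM in the same low range as compound 2. No separate measurement bears on this result, so the data give no reason for it.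

The compounds shown leave open how far this tolerance extends, since every group at this position is still a six-membered aromatic ring with 1 hetero atom. How a plain phenyl ring, a ring bearing a carboxylic acid or an amine, or an open alkyl chain would read at this position cannot be told from them.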